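The source may report more compounds than this note shows. Statements on the series, on what has been measured and on what is new or still open speak of the compounds shown alone.

Of the compounds shown here, two have been measured so far. Compound 1 `C/C(=N\OCC(=O)O)c1ccccc1O` was tested in a functional assay on the whole organism for inhibition, with Rattus norvegicus as the target, read by paw edema, with stated times of 1 h and 3 h, at a dose of 50 mg/kg by the oral route (on this read-out higher numbers stand for more inhibition at the one dose given (going by the name of the read-out) and lower numbers for less inhibition), and gives < 20%, which is a limit of the assay and not a number. The value of compound 1 sits at the limit of < 20% in this assay, at which 1 of the 2 values shown sits. Compound 2 `C/C(=N\OCC(=O)O)c1ccc(C)cc1` gives 20% in this assay. Among the two values shown, that of compound 2 is the only actual number; the other is a limit. Among the measured compounds shown here, no step between measured compounds that differ in one place is available, so there is no measured precedent for the move considered here.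

Compound 3 `C/C(=N\OCC(=O)O)c1ccc(C2CC2)cc1` has not yet been measured in this assay. It differs from compound 2 in one place: cyclopropyl in place of methyl on an aromatic carbon. For the measured compounds named here, with no measured step to lean on, the expectation for compound 3 rests on compound 2 alone, and the change is expected to carry no step beyond the usual scatter, so the expected step is a number 5 percentage points higher from compound 2 to compound 3 (within the scatter). Compound 3 is therefore estimated to give 25% in this assay, within a range from 10% to 45%, with a real chance that the assay reports only a limit for it.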

Compound 3, a percentage reported as inhibition, in the whole organism at one dose (the size of the read-out at that dose, not a potency): < 20%
Compound 3: only a limit was reported; the forecaster's own chance of this, stated with the estimate: 35%; middle value at least 5 percentage points away from the limit.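

Cyclopropyl in place of methyl, on an aromatic carbon para to a group of 8 heavy atoms, gives the first step at this place in this assay: it stands as a number no higher from compound 2 to compound 3 (the limit leaves the size open), and its size cannot be read. What it does show is that the entering three-membered ring of carbon brings no gain in inhibition over the methyl of compound 2 at the one dose given, although the size of the group goes up from 1 heavy atom to 3. Compound 2 remains the only compound shown with an actual number, and the others give only a limit: the limit of < 20% in this assay, at which 2 of the 3 values shown sit.

The compounds shown leave open how close compound 3 lies to compound 2, and whether any group on this aromatic carbon can lift the inhibition clearly past the value of compound 2. An amine, a carboxylic acid or a longer carbon chain at the same place would test this, and a real number for any of them would give this position its first step of readable size.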